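The source may hold more compounds than are shown below. What is called first, only, known or untested is meant among the compounds shown, and "the series" means these compounds.

Measured so far in a functional assay on Jurkat cells (Homo sapiens) for activation, with a stated time of 24 h; a lower number here means that less compound is needed, a higher number that more compound is needed for the effect:

- compound 1 `Oc1ccccc1CNc1ccc(-c2cccc(F)c2)cc1` gives 2020 nM
- compound 2 `Oc1ccccc1CNc1ccc(-c2cccc(Cl)c2)cc1` gives 6200 nM

Compound 2 stands at the higher of these two numbers, and its distance from compound 1 is a 3.1-fold higher number from compound 1 to compound 2 (0.49 log units; beyond the scatter), a modest but real difference that comes only from the swap of one halogen for another on the outer ring.

Compound 3 `Cc1ccccc1-c1ccc(NCc2ccccc2O)cc1` differs from compound 2 by 2-methylphenyl in place of 3-chlorophenyl on an aromatic carbon. Within the data shown here, only one measured step bears on this change, and it bears only loosely: the fluoro-to-chloro step shows that small changes on this outer ring move the number by a modest amount in this assay, but nothing measured here shows what a methyl, or a change in where the group sits on the ring, does. Compound 3 is therefore expected to land somewhere between the two measured numbers, so the expected step is a 1.6-fold lower number from compound 2 to compound 3 (0.19 log units; within the scatter), a modest lowering that may yet fall within the scatter. The estimate for compound 3 in this assay is 4000 nM, with a plausible range from 1500 nM to 12000 nM.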

Compound 3, half-maximal effective concentration: 5220 nM
Beside the measured number, compound 3's estimate is 1.3-fold (0.12 log units) below it; measured number inside the range.
By their numbers in this assay, from the lowest: compound 1; then compounds 3 and 2 (each within the scatter of the next).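

In this assay, 2-methylphenyl in place of 3-chlorophenyl gives a 1.2-fold lower number from compound 2 to compound 3 (0.07 log units; within the scatter), so compound 2 and compound 3 cannot be told apart even though both the group and its place on the outer ring differ. The same replacement of 3-fluorophenyl gives a 2.6-fold higher number from compound 1 to compound 3 (0.41 log units; beyond the scatter), which leaves compound 1 apart from the other two and shows that a ring bearing a halogen is not needed to match the number of compound 2. No available evidence says what lies behind these numbers.

From the compounds shown here alone, compound 3 changes the group and its place together, so the contribution of each stays open, and a 3-methylphenyl ring would separate them. Going by these compounds, how an amine or a carboxylic acid on this outer ring would read also remains open.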